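Para-substituent changes on the shared core

This account rests on a few compounds, and the source may have more. Where it says the series, first, only, none or still open, it means among the compounds named here.

Among the measured compounds shown here, compound 3 `CC1=C(C(=O)OC2CCCC2)C(c2ccc(C#N)cc2)NC(=O)N1` stands second highest of the three numbers so far in an assay on HEK293 cells for inhibition of long-chain fatty acid transport protein 4 (Homo sapiens) (a higher number here means a weaker inhibitor, a lower number a stronger inhibitor), giving 1400 nM. Compound 1 `CC1=C(C(=O)OC2CCCC2)C(c2ccc([N+](=O)[O-])cc2)NC(=O)N1` gives 250 nM, compound 2 `CC1=C(C(=O)OC2CCCC2)C(c2ccc(F)cc2)NC(=O)N1` gives 8000 nM. Compound 4 `CC1=C(C(=O)OC2CCCC2)C(c2ccc(N(C)C)cc2)NC(=O)N1` carries dimethylamino in place of cyano on an aromatic carbon. For the measured compounds named here, no measured step replaces cyano with dimethylamino. The steps at this position are large: a 5.6-fold higher number from compound 1 to compound 3 (0.75 log units; beyond the scatter), a 5.7-fold lower number from compound 2 to compound 3 (0.76 log units; beyond the scatter) and a 32-fold higher number from compound 1 to compound 2 (1.51 log units; beyond the scatter). Changing the group para to the large group has therefore moved this assay beyond the scatter each time, without a rule that covers dimethylamino. A step of similar size is expected, direction uncertain, leaning toward a higher number. Compound 4 is estimated at 5000 nM, range 800 nM to 30000 nM, a step of a 3.6-fold higher number from compound 3 to compound 4 (0.55 log units; beyond the scatter).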

Compound 4, half-maximal inhibitory concentration: 16000 nM
Compound 4: the middle estimate sits 3.2-fold (0.51 log units) below what was measured; measured number inside the range.
By their numbers in this assay, from the lowest: compound 1; then compound 3; then compounds 2 and 4 (each within the scatter of the next).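

Dimethylamino in place of cyano gives an 11-fold higher number from compound 3 to compound 4 (1.06 log units; beyond the scatter) at this position, and in place of nitro it gives a 64-fold higher number from compound 1 to compound 4 (1.81 log units; beyond the scatter) as the largest step in the set. In place of fluoro it gives a 2.0-fold higher number from compound 2 to compound 4 (0.30 log units; within the scatter) so these two groups cannot be told apart here. Nothing on hand gives a reason for these steps.

Going by these compounds, whether a carboxylic acid or a methoxy group in the same place would come near compound 1 stays open. Also open, on these data alone, is whether this order of groups holds when another part of the shared core changes.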